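The source may report more compounds than this note shows. Statements on the series, on what has been measured and on what is new or still open speak of the compounds shown alone.

Measured compounds:
compound 1 `CC(C)(C)Cc1cnc(CCc2ccc(-c3ccccc3C(=O)O)cc2)[nH]1`, 106 nM
compound 2 `O=C(O)c1ccccc1-c1ccc(CCc2ncc(Cc3ccc(F)cc3)[nH]2)cc1`, 1600 nM

In an in vitro functional assay on cells for agonist activity at Bombesin receptor subtype-3 (Homo sapiens), read by luminescence and calcium flux (on this read-out lower numbers stand for an effect already at smaller amounts and higher numbers for an effect only at larger amounts of compound), compound 2 gives the highest of the two numbers; its nearest neighbour is compound 1, and a 15-fold higher number from compound 1 to compound 2 (1.18 log units; beyond the scatter) separates them. Compound 3 `CC(C)(C)CCc1cnc(CCc2ccc(-c3ccccc3C(=O)O)cc2)[nH]1` is not yet measured. Compound 3 differs from compound 2 in that (neopentyl in place of 4-fluorophenyl on a saturated chain carbon bound to an aromatic carbon). Going by the values given here, the only step that bears on this is a 15-fold higher number from compound 1 to compound 2 (1.18 log units; beyond the scatter), which swapped an alkyl group for 4-fluorophenyl and gave a large rise. Reversing that kind of exchange, a large drop is expected, an 8.0-fold lower number from compound 2 to compound 3 (0.90 log units; beyond the scatter). Compound 3 is therefore estimated at 200 nM, with a range of 60 nM to 700 nM.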

Compound 3, half-maximal effective concentration: 39 nM
Beside the measured number, compound 3's estimate is 5.1-fold (0.71 log units) above it, and the stated range ends above it.
By their numbers in this assay, from the lowest: compound 3; then compound 1; then compound 2.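

In this assay, neopentyl in place of 4-fluorophenyl gives a 41-fold lower number from compound 2 to compound 3 (1.61 log units; beyond the scatter), so a group without a ring serves better at this place than the aromatic one. Neopentyl in place of tert-butyl gives a 2.7-fold lower number from compound 1 to compound 3 (0.43 log units; beyond the scatter), a modest step, so the outcome depends on which alkyl group sits here, not only on alkyl against aryl. No evidence at hand accounts for either step. Still open, from the compounds shown here alone, is whether a plain phenyl would behave like 4-fluorophenyl, and whether a longer chain or a cyclohexyl would lower the number further.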